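4-Bromophenyl in place of 1-methyl-1H-pyrrol-2-yl: weak cytotoxicity

The compounds below may be only part of what the source reports. "The series", "measured", "known", "first", "only" and "open" are said of these compounds alone.

Within the data shown here, in a functional assay on HepG2 cells (Homo sapiens) for cytotoxicity, read by MTT assay, with a stated time of 72 h (a lower number here means a stronger inhibitor, a higher number a weaker inhibitor), compound 1 `CCN1CCN(CCC(=O)Nc2ccc3[nH]c(-c4ccc(Br)cc4)nc3c2)CC1` gives 27400 nM as the only true number so far. Compound 2 `Cn1cccc1-c1nc2cc(NC(=O)CCCl)ccc2[nH]1` reads > 50000 nM and this is a limit, not a number. That leaves compound 2 at the limit of > 50000 nM in this assay, at which 1 of the 2 values shown sits, and gives it no exact place in the series.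

The step from compound 2 to compound 3 `O=C(CCCl)Nc1ccc2[nH]c(-c3ccc(Br)cc3)nc2c1` is a single change 4-bromophenyl in place of 1-methyl-1H-pyrrol-2-yl on an aromatic carbon that puts 4-bromophenyl in place of 1-methyl-1H-pyrrol-2-yl on an aromatic carbon of the shared core. Among the measured compounds shown here, no measured step covers this change, so the expectation rests on thin ground. Compound 1 also bears 4-bromophenyl and gives 27400 nM in this assay and on that basis a modest move toward stronger inhibition is expected. The estimated change is an at least 1.6-fold lower number from compound 2 to compound 3 (0.22 log units; that floor lies within the scatter) in the direction of stronger inhibition, and a reading that is again only a limit remains possible. Compound 3 is expected at 30000 nM with an estimated range from 10000 nM to 50000 nM as a working figure.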

Compound 3, half-maximal inhibitory concentration: 11300 nM
Estimate against measurement, compound 3: 2.7-fold (0.42 log units) above, within the range that was stated.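

In this assay, among these compounds, 4-bromophenyl in place of 1-methyl-1H-pyrrol-2-yl, on the aromatic carbon between two ring nitrogen atoms, gives an at least 4.4-fold lower number from compound 2 to compound 3 (0.64 log units; beyond the scatter), the first step to show that a change at this position moves the reading beyond the scatter. Going by these compounds, compound 2 remains a limit and not a number, so the step is a floor and its full size stays open: the limit of > 50000 nM in this assay, at which 1 of the 3 values shown sits. With 4-bromophenyl held constant, chloro in place of 4-ethylpiperazin-1-yl on a saturated chain carbon, two bonds along the chain from a carbonyl carbon, gives a 2.4-fold lower number from compound 1 to compound 3 (0.38 log units; beyond the scatter), which shows that the chain end also affects the reading and that the chloro compound is the stronger of this pair.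

Since the change at the aromatic carbon swaps the whole ring, the compounds shown do not separate the contribution of the bromine from that of the six-membered ring, and an unsubstituted phenyl would bear on this. Also open, on these data alone, are whether the step seen with the chloro chain carries over to a chain ending in 4-ethylpiperazin-1-yl, and how a chain ending in morpholine would read.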